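This account rests on a few compounds, and the source may have more. Where it says the series, first, only, none or still open, it means among the compounds named here.

Measured so far:
- compound 1 `O=C(NCc1ccccc1F)N1C(=O)c2ccccc2S1(=O)=O` gives 0.598 h
- compound 2 `O=C(c1ccccc1)N1Cc2ccccc2S1(=O)=O` gives > 166 h as a limit, not a number

For the measured compounds named here, both results come from a physicochemical assay for pharmacokinetics (on this read-out lower numbers stand for a shorter-lived compound and higher numbers for a longer-lived compound), and compound 1 holds the only actual number there. The next compound is compound 3 `O=C(NCc1ccc(Br)cc1)N1C(=O)c2ccccc2S1(=O)=O` with 4-bromophenyl in place of 2-fluorophenyl on a saturated chain carbon bound to an amide-type nitrogen as its change from compound 1, 4-bromophenyl in place of 2-fluorophenyl. Going by the values given here, no measured step shows what such an exchange does, so no step beyond the scatter is expected in this assay in either direction. The estimated size is a 1.0-fold higher number from compound 1 to compound 3 (0.00 log units; within the scatter) on that basis. The expected half-life of compound 3 is 0.6 h with an estimated range from 0.25 h to 1.5 h for repeat measurements.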

Compound 3, half-life: 0.187 h
Estimate against measurement, compound 3: 3.2-fold (0.51 log units) above; the whole stated range lies above it.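

In this assay the aryl group on a saturated chain carbon bound to an amide-type nitrogen is shown to matter: 4-bromophenyl in place of 2-fluorophenyl gives a 3.2-fold lower number from compound 1 to compound 3 (0.50 log units; beyond the scatter) on this read-out. The step is beyond the scatter, although both groups count as one six-membered aromatic ring of carbon only with 7 heavy atoms. Nothing measured here accounts for the step.

Going by these compounds, how 4-fluorophenyl and 2-bromophenyl would read remains open, and these would separate the halogen from where it sits. On these data alone, a carboxylic acid or an amine on that ring is equally open.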